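The source may report more compounds than this note shows. Statements on the series, on what has been measured and on what is new or still open speak of the compounds shown alone.

Measured so far in an ADME assay on cells (kidney, Cercopithecidae) for cytotoxicity (on this read-out higher numbers stand for weaker inhibition and lower numbers for stronger inhibition), each entry being a limit of the assay and not a number:

- compound 1 `NC(=O)c1cn(COC(CO)CO)c2ncnc(N)c12`: > 100000 nM
- compound 2 `N/C(=N\O)c1cn(COC(CO)CO)c2ncnc(N)c12`: > 100000 nM
- compound 3 `NC(=O)c1cn(C(CO)OC(CO)CO)c2ncnc(N)c12`: > 100000 nM

Compound 1 stands only at a limit, > 100000 nM, so it offers no number to start from. The whole set looks the same: the limit of > 100000 nM in this assay, at which 3 of the 3 values shown sit.

The next compound is compound 4 `Nc1ncnc2c1ccn2COC(CO)CO`. It differs from compound 1 as follows: hydrogen in place of carbamoyl on an aromatic carbon. In words, hydrogen sits in place of carbamoyl on an aromatic carbon.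

Among the compounds with values here, two measured steps bear on this. The first, a step that the two limits leave unreadable from compound 1 to compound 2, also replaces the carbamoyl group on that aromatic carbon. The second, a step that the two limits leave unreadable from compound 1 to compound 3, concerns the saturated chain instead. Neither has a readable size, and neither brought a number into this assay. Within the data shown here, no measured compound carries hydrogen on that aromatic carbon, so this change remains untested and the lower end of the range stays wide.

No step beyond the scatter is expected in either direction, and a further limit is the most likely read-out. The step expected is a number no higher from compound 1 to compound 4 (the limit leaves the size open). For compound 4 the estimated value is 100000 nM, with an expected range from 30000 nM to 300000 nM.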

Compound 4, half-maximal inhibitory concentration: > 100000 nM
Compound 4 was reported as a limit (the forecaster's own chance of this, stated with the estimate: 80%); the middle value lies on the limit itself.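

In this assay compound 4 gives > 100000 nM, a limit of the assay and not a number. Within the data shown here, no step to compound 4 from compound 1 or compound 2 can be read. The whole set reads the same: the limit of > 100000 nM in this assay, at which 4 of the 4 values shown sit. The compounds shown leave open whether any of these changes, including hydrogen in place of carbamoyl, shifts the read-out.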